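The source may report more compounds than this note shows. Statements on the series, on what has been measured and on what is new or still open speak of the compounds shown alone.

The series rests on a shared core, seen in compound 1 `CN(C)CCn1cnnc1-c1cc(Oc2ccc(NC(=O)N/N=C/c3cccc(O)c3)cc2F)ccn1`, compound 2 `CN(C)CCn1cnnc1-c1cc(Oc2ccc(NC(=O)N/N=C/c3ccc(F)cc3Cl)cc2F)ccn1`, compound 3 `CN(C)CCn1cnnc1-c1cc(Oc2ccc(NC(=O)N/N=C/c3cc(Br)c(O)c(Br)c3)cc2F)ccn1` and compound 4 `CN(C)CCn1cnnc1-c1cc(Oc2ccc(NC(=O)N/N=C/c3ccc(F)cc3)cc2F)ccn1`, and the four differ only in the aryl group attached to the carbon with a double bond to nitrogen. The read-out is an ADME assay on WI-38 cells (Homo sapiens) for cytotoxicity, read by MTT assay, with a stated time of 72 h; a lower number here means a stronger inhibitor, a higher number a weaker inhibitor. Of the three compounds already tested, only compound 2 carries a number: in this assay compound 2 gives 2090 nM. In this assay compound 3 stands at "not determined" (no result reported), and in this assay compound 1 is a further entry at "not determined" (no result reported), so compound 3 cannot be placed against any neighbour. Among the measured compounds shown here, no step between two measured compounds exists in this set, and nothing can be said about what the change from one aryl group to another has done so far.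

The change from compound 3 to compound 4 is 4-fluorophenyl in place of 3,5-dibromo-4-hydroxyphenyl on a carbon with a double bond to nitrogen. For the measured compounds named here, with no measured step to lean on, the size of the move in this assay cannot be drawn from the data; compound 2, which likewise bears a halogenated phenyl and gives 2090 nM, is the only anchor, and a result near it, neither clearly up nor clearly down beyond the scatter, is the reasonable expectation. For compound 4 in this assay the estimate is 3000 nM, with a range from 900 nM to 12000 nM.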

Compound 4, half-maximal inhibitory concentration: 3980 nM
Compound 4: the middle estimate sits 1.3-fold (0.12 log units) below what was measured, and the stated range covers the measured number.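

Compound 4 gives the series its first readable step at this position: hydrogen in place of chloro on an aromatic carbon yields a 1.9-fold higher number from compound 2 to compound 4 (0.28 log units; within the scatter) in this assay and so the two compounds cannot be told apart in this read-out. The finding rests on this one pair, with the 4-fluorophenyl group common to both and the chloro as the only difference, and it says nothing yet about aryl groups that carry a hydroxyl or bromine; steps involving compound 1 or compound 3 cannot be read, as neither has a number. No measured evidence accompanies this result that could account for it, so the step stands as an observation only.

The compounds shown leave open whether an amine or a carboxylic acid in place of the fluoro on the phenyl ring would keep the number in the same range as compound 2 and compound 4. They also leave open whether a methoxy group in place of the chloro would behave as hydrogen does here, or would move the number beyond the scatter.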